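The compounds below may be only part of what the source reports. "The series", "measured", "known", "first", "only" and "open" are said of these compounds alone.

Measured compounds in an assay on isolated protein for inhibition of Myeloperoxidase (Homo sapiens), read by ELISA, with a stated time of 5 min; on this read-out higher numbers stand for weaker inhibition and lower numbers for stronger inhibition:
- compound 1 `NCCSCCc1c[nH]c2ccc(F)cc12`: 8 nM
- compound 2 `NC(=O)CCc1c[nH]c2c(F)cccc12`: 64 nM

Compound 1 holds the lowest number of the two; compound 2 sits higher, and that gap lies beyond the scatter.

Compound 3 `CCNC(=O)CCCc1c[nH]c2ccc(F)cc12` is not yet measured. Against compound 1 it shows ((ethylcarbamoyl)methyl in place of (2-aminoethyl)sulfanyl on a saturated chain carbon, two bonds along the chain from an aromatic carbon). For the measured compounds named here, no measured pair isolates this change, so the step is uncertain; the expectation is that the number rises beyond the scatter, since compound 2 with its 64 nM is the only other point and sits well above compound 1. For compound 3 the estimated step is a 5.0-fold higher number from compound 1 to compound 3 (0.70 log units; beyond the scatter). Compound 3 is thus expected at 40 nM, with a range from 10 nM to 160 nM.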

Compound 3, half-maximal inhibitory concentration: 243 nM
Estimate against measurement, compound 3: 6.1-fold (0.78 log units) below, outside the stated range (above it).
By their numbers in this assay, from the lowest: compound 1; then compound 2; then compound 3.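

In this assay the step of a 30-fold higher number from compound 1 to compound 3 (1.48 log units; beyond the scatter) shows that the group on this saturated chain carbon, two bonds along the chain from an aromatic carbon, can by itself move the number a long way on the shared core. The change swaps (2-aminoethyl)sulfanyl for (ethylcarbamoyl)methyl, so the sulfur, the terminal amine and the amide all vary at once. No measurement at hand explains the step. As far as these compounds go, what remains open is which of these parts carries the difference. An all-carbon chain ending in a primary amine would separate the sulfur from the amine.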